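A few compounds are considered here, and "the series" means these few. Any claim that something is new, unique, unknown or untested is made for them only; others in the source may bear on it.

Measured so far:
Compound 1 `CCCCOc1ccc(C(=O)NNC(=O)c2ccc(NS(=O)(=O)c3cnc(O)nc3O)cc2)cc1`: 9010 nM
Compound 2 `Cc1ccc(C(=O)NNC(=O)c2ccc(NS(=O)(=O)c3cnc(O)nc3O)cc2)cc1`: 15900 nM

Among the compounds with values here, in a functional assay on A549 cells (Homo sapiens) for antiproliferative activity, read by MTT assay, with a stated time of 24 h (a lower number here means a stronger inhibitor, a higher number a weaker inhibitor), compound 2 gives 15900 nM, and only one other compound is available for comparison. That is compound 1 at 9010 nM, and the two numbers lie within the usual scatter of each other.

Compound 3 `O=C(NNC(=O)c1ccc(NS(=O)(=O)c2cnc(O)nc2O)cc1)c1ccc(F)cc1` keeps the shared core of compound 2 and makes one change, fluoro in place of methyl on an aromatic carbon, turning 4-methylphenyl into 4-fluorophenyl.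

Within the data shown here, no measured step makes this exact swap. The nearest evidence is a change on the same aromatic carbon, methyl in place of butoxy, which is a 1.8-fold higher number from compound 1 to compound 2 (0.25 log units; within the scatter). Among the measured compounds shown here, with only this step to go on, no shift beyond the scatter is expected in this assay.

The expected change is a 1.2-fold lower number from compound 2 to compound 3 (0.09 log units; within the scatter), which is too small to be told apart from the scatter. For compound 3, the estimated value is 13000 nM, with an expected range of 6000 nM to 28000 nM.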

Compound 3, half-maximal inhibitory concentration: > 20000 nM
Compound 3: only a limit was reported; the forecaster's own chance of this, stated with the estimate: 5%; middle value at least 1.5-fold (0.18 log units) away from the limit.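

In this assay compound 3 gives > 20000 nM as a limit of the assay, not as a number. Within the data shown here, the swap of 4-methylphenyl for 4-fluorophenyl reads as an at least 1.2-fold higher number from compound 2 to compound 3 (0.09 log units; that floor lies within the scatter), so that floor cannot separate the two, whereas fluoro in place of butoxy reads as an at least 2.2-fold higher number from compound 1 to compound 3 (0.34 log units; beyond the scatter), the first step at this position, para to a large group, to go beyond the scatter. Both steps are floors rather than sizes, and they stop where the assay stops: the limit of > 20000 nM in this assay, at which 1 of the 3 values shown sits.

On these data alone, how far compound 3 really lies from compound 2 stays open, and so does whether fluoro differs from methyl here at all. A longer chain such as hexyloxy, or an amine on the same carbon, would show whether this position tolerates other groups than these three.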